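This account rests on a few compounds, and the source may have more. Where it says the series, first, only, none or still open, it means among the compounds named here.

Series notes. In an ADME assay on L02 cells (Homo sapiens) for antiproliferative activity, read by MTT assay, with a stated time of 48 h (on this read-out lower numbers stand for stronger inhibition and higher numbers for weaker inhibition), compound 1 `Cc1cc(C)cc(-n2nncc2CN2C(=O)C3(C(C#N)=C(N)Oc4c3c3nc5ccccc5nc3c3ccccc43)c3ccccc32)c1` gives > 50000 nM, which is a limit of the assay. Compound 2 `Cc1ccccc1-n1nncc1CN1C(=O)C2(C(C#N)=C(N)Oc3c(N)cc4nc5ccccc5nc4c32)c2ccccc21` gives > 50000 nM, also a limit. Compound 3 `COc1ccc(-n2nncc2CN2C(=O)C3(C(C#N)=C(N)Oc4c(N)cc5nc6ccccc6nc5c43)c3ccccc32)cc1` gives > 50000 nM, again a limit, so for compound 3 only a limit stands, and the other two values shown are limits as well (the limit of > 50000 nM in this assay, at which 3 of the 3 values shown sit). The step that the two limits leave unreadable from compound 2 to compound 3 is therefore unreadable. Compound 4 `CCc1cccc(CC)c1-n1nncc1CN1C(=O)C2(C(C#N)=C(N)Oc3c(N)cc4nc5ccccc5nc4c32)c2ccccc21` differs from compound 3 by 2,6-diethylphenyl in place of 4-methoxyphenyl on an aromatic nitrogen. Going by the values given here, no measured step gives a readable size for a change on this aromatic nitrogen, so no step beyond the scatter is expected in this assay. The step that the limit leaves unreadable from compound 3 to compound 4 is an estimate only. For compound 4 the expected value in this assay is 80000 nM (range 30000 nM to 200000 nM), most probably once more reported as a limit.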

Compound 4, half-maximal inhibitory concentration: > 50000 nM
Compound 4: no number, only a limit (the forecaster's own chance of this, stated with the estimate: 85%); the middle value is on the limit's open side.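

The steps among compound 2, compound 3 and compound 4 cannot be read, because each value is a limit: the limit of > 50000 nM in this assay, at which 4 of the 4 values shown sit.

As far as these compounds go, whether any change on this aromatic nitrogen moves the read-out in this assay remains open.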